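The compounds below may be only part of what the source reports. "The series", "measured", "known", "first", "only" and "open" are said of these compounds alone.

Compound 2 `O=C(Nc1ccc(Oc2ccnc3[nH]ccc23)c(F)c1)c1nn(-c2ccccc2)ccc1=O` gives 38600 nM in a functional assay on PC-3 cells (Homo sapiens) for cytotoxicity, read by MTT assay, with a stated time of 72 h (a higher number here means a weaker inhibitor, a lower number a stronger inhibitor), and compound 1 `O=C(Nc1ccc(Oc2ccnc3[nH]ccc23)c(F)c1)c1nn(-c2ccc(Cl)cc2)ccc1=O` gives 42500 nM; the two numbers lie within the scatter of each other, so compound 2 stands level with compound 1 rather than apart from it. Compound 3 `O=C(Nc1ccc(Oc2ccnc3[nH]ccc23)c(F)c1)c1nn(-c2ccc(Cl)c(F)c2)ccc1=O` differs from compound 2 by 4-chloro-3-fluorophenyl in place of phenyl on an aromatic nitrogen. Among the measured compounds shown here, only one measured step bears on this: a 1.1-fold lower number from compound 1 to compound 2 (0.04 log units; within the scatter), and nothing measured speaks to the added fluorine. Compound 3 is therefore expected to show no step beyond the scatter, a 1.0-fold higher number from compound 2 to compound 3 (0.02 log units; within the scatter), and its estimated value is 40000 nM, within a range from 20000 nM to 80000 nM.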

Compound 3, half-maximal inhibitory concentration: 13600 nM
Estimate against measurement, compound 3: 2.9-fold (0.47 log units) above, outside the stated range (below it).
By their numbers in this assay, from the lowest: compound 3; then compounds 2 and 1 (each within the scatter of the next).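

On the ring carried by the aromatic nitrogen, swapping chloro for hydrogen made no difference beyond the scatter, yet adding one fluoro to the chloro-bearing ring gives a 3.1-fold lower number from compound 1 to compound 3 (0.49 log units; beyond the scatter) in this assay, the first real movement at this position. Replacing phenyl with 4-chloro-3-fluorophenyl gives a 2.8-fold lower number from compound 2 to compound 3 (0.45 log units; beyond the scatter), so the fluoro appears to matter here only alongside the chloro or on its own, which these data cannot separate. Nothing available explains why this step occurs.

From the compounds shown here alone, whether 3-fluorophenyl without the chloro would give the same step remains open. So does the effect of a methoxy group or a nitrile in the fluoro's place.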